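Nitro in place of chloro: expecting little change

The source may report more compounds than this note shows. Statements on the series, on what has been measured and on what is new or still open speak of the compounds shown alone.

Compound 1 `O=C(CCCCC(S)CCS)Nc1ccc(Cl)cc1` and compound 2 `O=C(CCCCC(S)CCS)Nc1cccc(C(F)(F)F)c1` have both been tested in a functional assay on KB cells (Homo sapiens) for inhibition, read by MTT assay, with a stated time of 24 h, tested at 0.1 ug/mL (a lower number here means less inhibition of growth, a higher number more inhibition of growth at the concentration tested), and their numbers sit close together. Among the compounds with values here, compound 1 gives 9.11% and compound 2 gives 8.41% here, which puts them within the scatter of each other, so compound 1 stands level with the only other measured compound. Compound 3 `O=C(CCCCC(S)CCS)Nc1ccc([N+](=O)[O-])cc1` has nitro in place of chloro on an aromatic carbon, para to a large group (nitro in place of chloro on an aromatic carbon). Within the data shown here, no measured pair shows a single change of this kind, so the evidence is thin. Among the measured compounds shown here, with compound 1 at 9.11% and compound 2 at 8.41% as the only guides, no step beyond the scatter is expected in this assay for this swap. The expected change stays within the scatter (a number 0.1 percentage points lower from compound 1 to compound 3 (within the scatter)). Compound 3 is estimated at 9% (range 2% to 20%).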

Compound 3, percent growth inhibition at one concentration: "not active" (no number reported)
Compound 3 has no reported number here; the estimate stays without a comparison.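

Within the data shown here, compound 3 is reported as not active, without a number, so no step from compound 1 to compound 3 can be read. From the compounds shown here alone, how far nitro in place of chloro shifts the result in this assay stays open. Nothing available explains this result.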